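Chloro in place of fluoro: working notes on the series

The source may report more compounds than this note shows. Statements on the series, on what has been measured and on what is new or still open speak of the compounds shown alone.

- Compound 1 `COc1ccc(Cl)cc1-n1ncc(-c2nnc(-c3ccc(F)cc3)o2)c1C` gives 4.26
- Compound 2 `COc1ccc(Cl)cc1-n1ncc(-c2nnc(-c3ccc(C)c(Br)c3)o2)c1C` gives 5.19

Both values come from a physicochemical assay for lipophilicity, using the shake flask method, measured as octanol-water partition; on this read-out higher numbers stand for higher lipophilicity and lower numbers for lower lipophilicity. Compound 1 stands lowest of the two numbers, with compound 2 as its nearest neighbour. Compound 3 `COc1ccc(Cl)cc1-n1ncc(-c2nnc(-c3ccc(Cl)cc3)o2)c1C`, not yet measured, has chloro in place of fluoro on an aromatic carbon, para to a large group (chloro in place of fluoro on an aromatic carbon). For the measured compounds named here, the only measured step bearing on this is a number 0.93 log units higher from compound 1 to compound 2 (beyond the scatter), a modest one for 3-bromo-4-methylphenyl in place of 4-fluorophenyl, a larger exchange than this one. A smaller step in the same upward direction is expected in this assay, namely a number 0.49 log units higher from compound 1 to compound 3 (beyond the scatter). The estimate for compound 3 is 4.75, with an expected range of 4.45 to 5.1.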

Compound 3, partition coefficient: 4.51
For compound 3 the middle estimate is 0.24 log units above the measured one; the measured number falls inside the stated range.
By their numbers in this assay, from the lowest: compounds 1 and 3 (each within the scatter of the next); then compound 2.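

In this assay, chloro in place of fluoro on this aromatic carbon gives a number 0.25 log units higher from compound 1 to compound 3 (within the scatter), so this exchange of one halogen for another does not separate the two compounds. The larger exchange does register, with a number 0.68 log units lower from compound 2 to compound 3 (beyond the scatter). Compound 2 therefore stands clear of both compound 1 and compound 3, and the step from 4-fluorophenyl to 4-chlorophenyl alone accounts for no comparable shift.

As far as these compounds go, how an amine or a carboxylic acid on this aromatic carbon would read in this assay remains open. Nothing available explains either step.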